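Swapping an imidazole for a piperazine on one side arm

The compounds below may be only part of what the source reports. "The series", "measured", "known", "first", "only" and "open" are said of these compounds alone.

Three compounds that share a core were tested in an ADME assay on HepG2 cells (Homo sapiens) for cytotoxicity, read by neutral red uptake, with a stated time of 24 h; on this read-out higher numbers stand for lower toxicity in this test and lower numbers for higher toxicity in this test. Compound 1 `Clc1cccc(C(Nc2ccnc3cc(Cl)ccc23)c2ccc(CN3CCCC3)cc2)c1` gives 31 uM in this assay. Compound 2 `Clc1ccc2c(NC(c3ccccc3)(c3ccc(CN4CCCC4)c(Cl)c3)c3ccc(CN4CCCC4)c(Cl)c3)ccnc2c1` gives 6.1 uM in this assay. Compound 3 `Clc1ccc(C(Nc2ccnc3cc(Cl)ccc23)c2ccc(Cn3ccnc3)cc2)cc1` gives 22 uM in this assay. On these numbers compound 3 stands second highest of the three: its value and that of compound 1 lie within the usual scatter of each other, so nothing separates them, while compound 2 sits beyond the scatter at a lower value.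

Compound 4 `Clc1ccc(C(Nc2ccnc3cc(Cl)ccc23)c2ccc(CN3CCNCC3)cc2)cc1` has not yet been measured. It differs from compound 3 in one place: piperazin-1-yl in place of 1H-imidazol-1-yl on a saturated chain carbon bound to an aromatic carbon. The rest of the molecule is unchanged.

For the measured compounds named here, no measured pair differs in exactly this way, so the size of the step cannot be read from a neighbouring pair. What can be said is that compound 1, which carries a saturated ring amine at the corresponding position, gives 31 uM, and that this lies within the scatter of compound 3. A step within the scatter is therefore expected, a 1.1-fold higher number from compound 3 to compound 4 (0.06 log units; within the scatter), with no clear direction. Compound 4 is expected to give about 25 uM in this assay, within a range from 10 uM to 60 uM.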

Compound 4, half-maximal toxic concentration: 1.8 uM
Compound 4: middle estimate off by 14-fold (1.14 log units), on the high side; the measured number lies below the stated range.
By their numbers in this assay, from the lowest: compound 4; then compound 2; then compounds 3 and 1 (each within the scatter of the next).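

Read in this assay, this is the first step between two compounds that differ in one place, and it is large: piperazin-1-yl in place of 1H-imidazol-1-yl gives a 12-fold lower number from compound 3 to compound 4 (1.09 log units; beyond the scatter) with the rest of the molecule unchanged. The result shows that this position, on a saturated chain carbon bound to an aromatic carbon, is not indifferent to the group it carries, since exchanging a five-membered aromatic ring without a hydrogen-bond donor for a six-membered non-aromatic ring with one hydrogen-bond donor goes with much higher toxicity in this test. Nothing available here shows which feature of this exchange accounts for the step.

The ring hydrogen-bond donor and the loss of the aromatic ring change together in this pair, so the two cannot be told apart; 4-methylpiperazin-1-yl or morpholin-4-yl at the same place would bear on that question. As far as these compounds go, it also remains open whether the same exchange would give a step of this size on the other side arms and substitution patterns seen, such as those of compound 2.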